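Replacing the Ring Group on the Amine Nitrogen

The source may report more compounds than this note shows. Statements on the series, on what has been measured and on what is new or still open speak of the compounds shown alone.

Measured so far:
compound 1, `CNCC1CCCc2cc(S(=O)(=O)c3ccccc3)ccc21`: 0.316 nM
compound 2, `O=C1CN=C(NC[C@@H]2CCCc3cc(S(=O)(=O)c4cccc(F)c4)ccc32)N1`: 0.1 nM

Both were tested in an assay on isolated protein for displacement of a labelled ligand from 5-hydroxytryptamine receptor 6 (Homo sapiens); on this read-out lower numbers stand for stronger inhibition and higher numbers for weaker inhibition. Compound 2 gives the lower of the two numbers; compound 1 gives a higher number, a gap beyond the usual scatter. Compound 3, `O=C(CO)NC[C@@H]1CCCc2cc(S(=O)(=O)c3cccc(F)c3)ccc21`, has not yet been measured. It differs from compound 2 in one place: a group of 4 heavy atoms (2 carbon, 2 oxygen; no ring) in place of a group of 6 heavy atoms (3 carbon, 2 nitrogen, 1 oxygen; one five-membered non-aromatic ring with 2 hetero atoms), on an amine nitrogen. Among the measured compounds shown here, no comparable pair has been measured, so the expectation rests on the change itself: a sizeable move toward a higher number is expected, a 200-fold higher number from compound 2 to compound 3 (2.30 log units; beyond the scatter). For compound 3 the estimate in this assay is 20 nM, within 3 nM to 200 nM.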

Compound 3, inhibition constant: 0.1 nM
For compound 3 the middle estimate is 200-fold (2.30 log units) above the measured one; measured number outside the range, below it.
By their numbers in this assay, from the lowest: compounds 2 and 3 (each within the scatter of the next); then compound 1.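

In this assay, putting (hydroxymethyl)carbonyl in place of the ring group on the amine nitrogen gives no change at the digits printed from compound 2 to compound 3 (within the scatter). At this position, then, the five-membered ring is not required to keep the number this low, at least in this one pair, where both groups carry 1 hydrogen-bond donor and 2 hydrogen-bond acceptors. No measurement at hand accounts for this result.

Going by these compounds, it remains open whether a plain acetyl group, lacking the hydroxyl, would match these two compounds. The same question applies to a longer chain or a carboxylic acid at this nitrogen.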